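Nitrophenyl-furan pyrrolidines: amine swap at the anilino position

A few compounds are considered here, and "the series" means these few. Any claim that something is new, unique, unknown or untested is made for them only; others in the source may bear on it.

Among the measured compounds shown here, the three measured members share one core. Compound 3 `CN(C)c1cccc(C2CCCN2Cc2ccc(-c3ccccc3[N+](=O)[O-])o2)c1` is the point of departure; in an ADME assay on microsomes from liver (Mus musculus, strain CD-1) for metabolic stability, read by LC-MS, using NADPH, with a stated time of 60 min, tested at 1 uM (a higher number here means that the compound lasts longer, a lower number that the compound disappears faster), compound 3 gives 0.013 h, the lowest of the three numbers, though compound 1 `CN(C)c1ccc(C2CCCN2Cc2ccc(-c3ccccc3[N+](=O)[O-])o2)cc1` with 0.0158 h and compound 2 `O=[N+]([O-])c1ccccc1-c1ccc(CN2CCCC2c2ccc(N3CCCCC3)cc2)o1` with 0.0215 h both sit within the scatter of it. For the measured compounds named here, the step of a 1.2-fold lower number from compound 1 to compound 3 (0.08 log units; within the scatter) and the step of a 1.4-fold higher number from compound 1 to compound 2 (0.13 log units; within the scatter) are both within the scatter, so nothing measured so far has moved this assay.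

Compound 4 `O=[N+]([O-])c1ccccc1-c1ccc(CN2CCCC2c2cccc(N3CCCC3)c2)o1` differs from compound 3 in one place: pyrrolidin-1-yl in place of dimethylamino on an aromatic carbon. The most closely related measured step is a 1.4-fold higher number from compound 1 to compound 2 (0.13 log units; within the scatter), where a cyclic amine also replaced dimethylamino on the aromatic carbon and the number barely moved. On that basis the step from compound 3 to compound 4 is expected to stay within the scatter, with no clear direction, estimated at a 1.2-fold higher number from compound 3 to compound 4 (0.09 log units; within the scatter). For compound 4 the expected half-life in this assay is 0.016 h, with a range from 0.008 h to 0.032 h.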

Compound 4, half-life: 0.0935 h
Beside the measured number, compound 4's estimate is 5.8-fold (0.77 log units) below it; measured number outside the range, above it.
By their numbers in this assay, from the lowest: compounds 3, 1 and 2 (each within the scatter of the next); then compound 4.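

Among the compounds shown here, at the aromatic carbon meta to a large group, pyrrolidin-1-yl in place of dimethylamino gives the first step beyond the scatter in this assay (a 7.2-fold higher number from compound 3 to compound 4 (0.86 log units; beyond the scatter)), so the amine at this position can move the half-life. Replacing dimethylamino with a cyclic amine does not have a single outcome across the compounds shown: the other such change, with piperidin-1-yl at a different place on the ring, stayed within the scatter (a 1.4-fold higher number from compound 1 to compound 2 (0.13 log units; within the scatter)). No measured property available here bears on the rise in half-life.

Still open, from the compounds shown here alone, is whether the step follows the ring size of the amine, its place on the aromatic ring, or both. Azetidin-1-yl, piperidin-1-yl or morpholin-4-yl at the same carbon as in compound 4 would show how far the result extends to other cyclic amines.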